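The source may hold more compounds than are shown below. What is called first, only, known or untested is meant among the compounds shown, and "the series" means these compounds.

Measured in a functional assay on KB cells (Homo sapiens) for antiproliferative activity, read by MTT assay, with a stated time of 72 h; a lower number here means a stronger inhibitor, a higher number a weaker inhibitor:
- compound 1 `CCOC(=O)c1cc(-c2cc(OC)c(OC)c(OC)c2)c(-c2ccc(OC)c(O)c2)s1`: 1250 nM
- compound 2 `COc1ccc(-c2sc(C(=O)O)cc2-c2cc(OC)c(OC)c(OC)c2)cc1[N+](=O)[O-]`: 35900 nM
- compound 3 `COc1cc(-c2cc(C(=O)O)sc2-c2ccc3ccccc3c2)cc(OC)c1OC`: 5640 nM

Compound 3, at 5640 nM, holds the middle place of the three, with a lower number for compound 1 and a higher number for compound 2, both gaps beyond the scatter.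

The next compound is compound 4 `COc1ccc(-c2sc(C(=O)O)cc2-c2cc(OC)c(OC)c(OC)c2)cc1O`, which has 3-hydroxy-4-methoxyphenyl in place of naphthalen-2-yl on an aromatic carbon.

Among the compounds with values here, no measured pair isolates this change. Compound 1 carries the same 3-hydroxy-4-methoxyphenyl and gives 1250 nM, but it has an ethyl ester where compound 4 has the carboxy group, so it is only a loose guide. Compound 4 shares the carboxy group with compound 2, which gives 35900 nM, and this shows how far the number can move with the group at this place.

The expected change is a modest one toward a lower number, estimated as a 2.3-fold lower number from compound 3 to compound 4 (0.35 log units; beyond the scatter). For compound 4 the estimated value is 2500 nM, expected within 500 nM to 12000 nM.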

Compound 4, half-maximal inhibitory concentration: 11200 nM
Compound 4: the middle estimate sits 4.5-fold (0.65 log units) below what was measured; the range from low to high includes it.
By their numbers in this assay, from the lowest: compound 1; then compounds 3 and 4 (each within the scatter of the next); then compound 2.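

With the carboxy group kept, 3-hydroxy-4-methoxyphenyl in place of naphthalen-2-yl, on the aromatic carbon next to the ring sulfur, gives a 2.0-fold higher number from compound 3 to compound 4 (0.30 log units; within the scatter), so this assay does not separate these two groups at this place. Hydroxy in place of nitro on an aromatic carbon gives a 3.2-fold lower number from compound 2 to compound 4 (0.51 log units; beyond the scatter), which shows that a single substituent on the phenyl group at this place can move the number even though the swap of the whole group does not. With 3-hydroxy-4-methoxyphenyl kept, hydrogen in place of ethyl on an oxygen next to a carbonyl group gives a 9.0-fold higher number from compound 1 to compound 4 (0.95 log units; beyond the scatter), so the ethyl ester and the carboxy group differ clearly here.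

Going by these compounds, it remains open whether an amine in place of the hydroxy would follow the hydroxy or the nitro, and whether the ethyl ester step carries over to naphthalen-2-yl. Nothing at hand gives a cause for any of these steps.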